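Swapping a methoxy for a methyl on the benzoyl ring

The compounds below may be only part of what the source reports. "The series", "measured", "known", "first", "only" and "open" are said of these compounds alone.

The series rests on a shared core seen in compound 1 `COC(=O)c1c(Nc2ccc(C)cc2)sc(C(=O)c2ccc(OC)cc2)c1C`, compound 2 `COC(=O)c1c(Nc2ccc(OC)cc2)sc(C(=O)c2ccc(OC)cc2)c1C` and compound 3 `COC(=O)c1c(Nc2ccc(F)cc2)sc(C(=O)c2ccc(OC)cc2)c1C`. In a functional assay, with a stated time of 150 min, tested at 5 ug/mL (a higher number here means a stronger effect of the compound at the concentration tested, a lower number a weaker effect), compound 1 is reported as "not active" (no number reported), with no number given. In this assay compound 2 gives 4.29%, and compound 3 gives 5.28%. Going by the values given here, the single measured step, a number 1 percentage points higher from compound 2 to compound 3 (within the scatter), lies within the scatter, so compound 3 stands as the higher of two numbers that cannot be told apart, with compound 1 beside them without a number.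

Compound 4 `COC(=O)c1c(Nc2ccc(F)cc2)sc(C(=O)c2ccc(C)cc2)c1C` differs from compound 3 as follows: methyl in place of methoxy on an aromatic carbon. Among the compounds with values here, no measured step addresses a change at this position: the step from compound 2 to compound 3 concerns the other aromatic ring, and compound 1, which carries a methyl on that other ring, has no number. Within the data shown here, all numbers so far sit low and close together, and the only known step is small. The expectation for compound 4 in this assay is therefore a step of a number 0.3 percentage points lower from compound 3 to compound 4 (within the scatter), not beyond the scatter. Compound 4 is estimated at 5%, with a range from 0% to 12%.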

Compound 4, a percentage reported as activity, at one concentration (the size of the read-out at that concentration, not a potency): "not active" (no number reported)
No number was reported for compound 4, so the estimate cannot be set against anything.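

In this assay, going by these compounds alone, compound 4 gives "not active" (no number reported), so no step from compound 3 to compound 4 can be read. Nothing shown here bears on this result. The compounds shown leave open how far the change from 4-methoxyphenyl to 4-methylphenyl moves the read-out when both partners carry a number.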